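A Second Methoxy Group Added to Compound 1

A few compounds are considered here, and "the series" means these few. Any claim that something is new, unique, unknown or untested is made for them only; others in the source may bear on it.

Compound 1 `COc1ccc(-c2nnc(SC/C(=N/O)c3ccccc3)n2-c2ccccc2)cc1`: 63%
Compound 2 `CCn1c(SCC(=O)c2ccccc2)nnc1-c1ccc(OC)cc1`: 67%

Of the compounds shown here, two have been measured in a functional assay on the whole organism (strain albino) for inhibition, with Rattus norvegicus as the target, read by paw edema, with a stated time of 3 h, at a dose of 0.28 mmol/kg by the oral route; a higher number here means more inhibition at the dose given (going by the name of the read-out), a lower number less inhibition. Compound 1 gives 63%, and compound 2 gives 67%; the gap between these two numbers lies within the usual scatter of this assay, so the two cannot be told apart, and compound 1 does not stand apart from its neighbour. Among the measured compounds shown here, no step between measured compounds that differ in a single place is available here.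

Compound 3 `COc1ccc(-c2nnc(SC/C(=N/O)c3ccccc3)n2-c2ccccc2)cc1OC` differs from compound 1 by a single change: methoxy in place of hydrogen on an aromatic carbon. For the measured compounds named here, with no comparable step among the measured compounds to lean on, the expected step from compound 1 to compound 3 is estimated as small, in no fixed direction, as no change at the digits printed from compound 1 to compound 3 (within the scatter), not beyond the scatter. Compound 3 is therefore expected to give about 63% in this assay, within a range from 45% to 80%.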

Compound 3, a percentage reported as inhibition, in the whole organism at one dose (the size of the read-out at that dose, not a potency): 67%
Compound 3: middle estimate off by 4 percentage points, on the low side, within the range that was stated.
By their numbers in this assay, from the lowest: compounds 1, 2 and 3 (each within the scatter of the next).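

Among the compounds shown here, this is the first comparison in the set between compounds that differ in one place: the methoxy enters on an aromatic carbon, ortho to a methoxy group and meta to a large group, turning 4-methoxyphenyl into 3,4-dimethoxyphenyl. In this assay the outcome is a number 4 percentage points higher from compound 1 to compound 3 (within the scatter), so at this single dose and time the added group brings no difference that can be read at this position. Nothing available bears on the reason for this result.

Going by these compounds, whether a hydroxy group, an amine or a longer alkoxy chain on the same aromatic carbon would also stay within the scatter remains open. As the read-out comes from one dose, the compounds shown also leave open whether compound 1 and compound 3 would differ in potency.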